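The compounds below may be only part of what the source reports. "The series", "measured", "known", "first", "only" and "open" are said of these compounds alone.

In a functional assay on MDBK cells (Bos taurus) for cytotoxicity (a higher number here means that more compound is tolerated, a lower number that less compound is tolerated), compound 3 `Cc1ccc(O)c(C(=O)NCCCN2CCC[C@@H]3CCCC[C@H]32)c1` gives 60 ug/mL. Within the data shown here, of the two numbers known it holds the higher one, but its nearest neighbour, compound 2 `O=C(NCCCN1CCC[C@@H]2CCCC[C@@H]21)c1cc(Cl)ccc1O`, gives 43 ug/mL, and that gap lies within the scatter. Compound 1 `Cc1ccc(O)c(C(=O)NCCCN2CCC[C@@H]3CCCC[C@@H]32)c1` gives only a limit of the assay, > 100 ug/mL. Compound 4 `O=C(NCCCN1CCC[C@@H]2CCCC[C@H]21)c1cc(Cl)ccc1O` differs from compound 3 in one place: chloro in place of methyl on an aromatic carbon. The same exchange was measured once, from compound 1 to compound 2, with an at least 2.3-fold lower number from compound 1 to compound 2 (0.36 log units; beyond the scatter), a step whose size is known only as a floor because of the limit of > 100 ug/mL in this assay, at which 1 of the 3 values shown sits. The other known step, an at least 1.6-fold lower number from compound 1 to compound 3 (0.22 log units; that floor lies within the scatter), rests on the same floor. For compound 4 a drop of similar size is therefore expected, giving a 1.9-fold lower number from compound 3 to compound 4 (0.27 log units; within the scatter) and an estimated 32 ug/mL, with a range from 14 ug/mL to 75 ug/mL.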

Compound 4, half-maximal cytotoxic concentration: 45 ug/mL
The estimate for compound 4 lay 1.4-fold (0.15 log units) below the measured number; low and high end bracket the measured number.
By their numbers in this assay, from the lowest: compounds 2, 4 and 3 (each within the scatter of the next). At a limit, above all of these: compound 1.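

In this assay, the exchange of methyl for chloro now has a step read between two real numbers, with no limit at either end: a 1.3-fold lower number from compound 3 to compound 4 (0.12 log units; within the scatter). Among the chloro compounds, the stereocentre that separates them shows no difference beyond the scatter, with a 1.0-fold higher number from compound 2 to compound 4 (0.02 log units; within the scatter). Whether the exchange has the same size on both cores cannot be settled: the same change on two cores in this assay, an at least 2.3-fold lower number (0.36 log units; beyond the scatter) from compound 1 to compound 2 and a 1.3-fold lower number (0.12 log units; within the scatter) from compound 3 to compound 4; the limit leaves it open whether they differ. The compounds shown leave open how a fluoro, a methoxy or an amine would read at this place, para to a hydroxy group.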